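This account rests on a few compounds, and the source may have more. Where it says the series, first, only, none or still open, it means among the compounds named here.

Compound 1, `O=C(Nc1ccccc1[N+](=O)[O-])N[C@H]1CC[C@H](Oc2ccc(F)cc2)CC1`, gives 3500 nM in a functional assay on CRL2813 cells (Homo sapiens) for cytotoxicity, read by sulforhodamine B assay, with a stated time of 5 days; a lower number here means a stronger inhibitor, a higher number a weaker inhibitor. Going by the values given here, compound 2, `COc1cccc(NC(=O)N[C@H]2CC[C@H](Oc3ccc(F)cc3)CC2)c1`, gives 14000 nM in this assay and thus carries the higher of the two numbers measured so far, standing apart from compound 1 by the step of a 4.0-fold higher number from compound 1 to compound 2 (0.60 log units; beyond the scatter). Compound 3, `O=C(Nc1cccc(C(=O)O)c1)N[C@H]1CC[C@H](Oc2ccc(F)cc2)CC1`, differs from compound 2 by carboxy in place of methoxy on an aromatic carbon. Among the compounds with values here, the only step measured so far, the one from compound 1 to compound 2, changes a different part of the molecule, the aryl group itself rather than a substituent on the 3-position of a fixed phenyl, so no measured step bears directly on the exchange of methoxy for carboxy. The series gives no precedent in either direction, and a change confined to the scatter is therefore the plainest expectation, with a wide allowance for the unknown. For compound 3 the number expected in this assay is 18000 nM, within 6000 nM to 55000 nM, a step of a 1.3-fold higher number from compound 2 to compound 3 (0.11 log units; within the scatter) expected from compound 2.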

Compound 3, half-maximal inhibitory concentration: > 20000 nM
Compound 3: a limit, no number (the forecaster's own chance of this, stated with the estimate: 15%); middle value at least 1.1-fold (0.04 log units) away from the limit.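

In this assay compound 3 gives no number, only a limit: the limit of > 20000 nM in this assay, at which 1 of the 3 values shown sits. Carboxy in place of methoxy, meta to a large group, gives an at least 1.4-fold higher number from compound 2 to compound 3 (0.15 log units; that floor lies within the scatter), so this exchange shows no gain in strength, but its true size remains unknown and a clear loss is not established. The comparison with the 2-nitrophenyl group is firmer, with an at least 5.7-fold higher number from compound 1 to compound 3 (0.75 log units; beyond the scatter), which places the 3-carboxyphenyl compound clearly on the weaker side of compound 1.

How far compound 3 lies past its limit cannot be read from these values. From the compounds shown here alone, what a methyl ester or a primary amine would give at this place remains open, as does whether a carboxylic acid elsewhere on the same ring would return a measurable number.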